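Amide nitrogen methylation in the quinoline ether anilide series

The compounds below may be only part of what the source reports. "The series", "measured", "known", "first", "only" and "open" are said of these compounds alone.

Measured so far:
Compound 1 `COc1ccc2nc(C)cc(OCC(=O)Nc3cc(C)cc(C)c3)c2c1`: 26000 nM
Compound 2 `CCCc1cc(OCC(=O)Nc2cc(C)cc(C)c2)c2cc(OC)ccc2n1`: 12000 nM
Compound 3 `COc1ccc2nc(C)cc(OC(C)C(=O)Nc3cc(C)cc(C)c3)c2c1`: 61000 nM

In a physicochemical assay for solubility, in phosphate buffer, measured as kinetic solubility, with a stated time of 1 h, at pH 7.4 (a lower number here means a less soluble compound, a higher number a more soluble compound), compound 1 holds the second highest of the three numbers, sitting between compound 2 and compound 3. The step of a 2.2-fold lower number from compound 1 to compound 2 (0.34 log units; beyond the scatter) and the step of a 2.3-fold higher number from compound 1 to compound 3 (0.37 log units; beyond the scatter) both alter the chain or ring carbons, not the amide. Compound 4 `COc1ccc2nc(C)cc(OCC(=O)N(C)c3cc(C)cc(C)c3)c2c1` differs from compound 1 by methyl in place of hydrogen on an amide-type nitrogen. Among the measured compounds shown here, no measured step touches the amide nitrogen, so neither step bears directly on this change; both show that single small additions move this assay only modestly, in either direction. A modest shift is therefore expected, with direction uncertain, expressed as a 1.5-fold higher number from compound 1 to compound 4 (0.19 log units; within the scatter). For compound 4 in this assay the estimate is 40000 nM, within the range 15000 nM to 110000 nM.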

Compound 4, solubility: 373000 nM
The estimate for compound 4 lay 9.3-fold (0.97 log units) below the measured number, outside the stated range (above it).
By their numbers in this assay, from the lowest: compound 2; then compound 1; then compound 3; then compound 4.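

In this assay the amide nitrogen gives the largest response of the three places changed: a 14-fold higher number from compound 1 to compound 4 (1.16 log units; beyond the scatter) is a large step, against the modest 2.2-fold lower number from compound 1 to compound 2 (0.34 log units; beyond the scatter) and a 2.3-fold higher number from compound 1 to compound 3 (0.37 log units; beyond the scatter) on saturated chain carbons. One added carbon on this nitrogen, with the amide hydrogen gone, suffices for a step of this size. Nothing available accounts for the step.

Going by these compounds, whether a longer chain, such as propyl, or a chain carrying an amine on this nitrogen gives a similar step remains open. Also open, on these data alone, is whether the step persists when the nitrogen methyl is combined with the chain changes in compound 2 or compound 3.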